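From Propoxy to Tert-Butyl on a Shared Core

This account rests on a few compounds, and the source may have more. Where it says the series, first, only, none or still open, it means among the compounds named here.

Going by the values given here, compound 2 `CCCOc1ccc(S(=O)(=O)NC(=O)Nc2ccc(Cl)cc2)s1` has the highest of the two numbers so far in a functional assay on the whole organism (6C3HED cells, Mus musculus) for inhibition, at a dose of 150 mg/kg by the oral route (on this read-out higher numbers stand for more inhibition at the one dose given (going by the name of the read-out) and lower numbers for less inhibition), where compound 2 gives 44%. Its nearest neighbour, compound 1 `CC(C)c1ccc(S(=O)(=O)NC(=O)Nc2ccc(Cl)cc2)s1`, gives 42% in this assay, and the step of a number 2 percentage points higher from compound 1 to compound 2 (within the scatter) lies within the scatter, so the two cannot be told apart. Compound 3 `CC(C)(C)c1ccc(S(=O)(=O)NC(=O)Nc2ccc(Cl)cc2)s1` remains to be measured in this assay. It differs from compound 2 in one place: tert-butyl in place of propoxy on an aromatic carbon. Among the compounds with values here, only one measured step bears on this change, a number 2 percentage points higher from compound 1 to compound 2 (within the scatter), which also exchanged one group for another at the same aromatic carbon and moved the read-out by an amount within the scatter. No larger effect is therefore expected here. Compound 3 is expected to give 43% in this assay, with a likely range from 30% to 56%. The estimate means an expected step of a number 1 percentage points lower from compound 2 to compound 3 (within the scatter), none beyond the scatter.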

Compound 3, a percentage reported as inhibition, in the whole organism at one dose (the size of the read-out at that dose, not a potency): 7%
Compound 3: the middle estimate sits 36 percentage points above what was measured, outside the stated range (below it).
By their numbers in this assay, from the lowest: compound 3; then compounds 1 and 2 (each within the scatter of the next).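

At this place on the shared core, next to the ring sulfur, the read-out turned out to depend strongly on the group: in this assay tert-butyl in place of propoxy gave a number 37 percentage points lower from compound 2 to compound 3 (beyond the scatter), although both groups hold 4 heavy atoms, so that count alone does not set the read-out. One methyl in place of hydrogen on the saturated chain carbon of isopropyl was enough for a step of similar size, a number 35 percentage points lower from compound 1 to compound 3 (beyond the scatter), whereas the exchange between compound 1 and compound 2 had shown no change beyond the scatter. Nothing measured here accounts for this loss of inhibition.

The compounds shown leave open whether the low number belongs to tert-butyl alone or would return with other groups at this place. Cyclopropyl, ethyl or a longer chain such as butoxy would each bear on that question.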